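The source may report more compounds than this note shows. Statements on the series, on what has been measured and on what is new or still open speak of the compounds shown alone.

Compound 1 `COC(=O)c1c(Nc2ccccc2)sc(C(=O)c2ccc(C)cc2)c1C`: 9.35%
Compound 2 `COC(=O)c1c(Nc2ccc(F)cc2)sc(C(=O)c2ccc(C)cc2)c1C`: "not active" (no number reported)
Compound 3 `Cc1ccc(C(=O)c2sc(Nc3ccccc3)c(C(=O)O)c2C)cc1`: 5.13%

In a functional assay, with a stated time of 150 min, tested at 30 ug/mL (a higher number here means a stronger effect of the compound at the concentration tested, a lower number a weaker effect), compound 3 gives the lower of the two numbers reported, with compound 1 the nearest. Within the data shown here, the only measured step that joins two compounds is a number 4.2 percentage points lower from compound 1 to compound 3 (within the scatter), and it lies within the scatter, so compound 3 and compound 1 cannot be told apart on these data; that step is also a different change, the ester to the acid, and so bears on the new compound only as a sign that the acid keeps a read-out much like the ester.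

Compound 4 `Cc1ccc(C(=O)c2sc(Nc3ccc(F)cc3)c(C(=O)O)c2C)cc1` differs from compound 3 by fluoro in place of hydrogen on an aromatic carbon. Among the measured compounds shown here, no measured step covers this change directly, but the same swap separates compound 1 from compound 2: compound 1 gives 9.35%, while compound 2 is reported as "not active" (no number reported). On that pair, a drop to a small number, or to no number at all, is the expected outcome for compound 4, as a step of a number 3.1 percentage points lower from compound 3 to compound 4 (within the scatter). Compound 4 is therefore estimated at 2%, between 0% and 8%.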

Compound 4, a percentage reported as activity, at one concentration (the size of the read-out at that concentration, not a potency): "not active" (no number reported)
No number was reported for compound 4, so the estimate cannot be set against anything.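

Among these compounds, compound 4 is reported as "not active" without a number, and no step from compound 3 to compound 4 can be read from it. The compounds shown leave open whether compound 2 and compound 4, with their 4-fluorophenyl group, truly differ from compound 1 and compound 3. Nothing measured here offers an explanation.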